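A few compounds are considered here, and "the series" means these few. Any claim that something is new, unique, unknown or untested is made for them only; others in the source may bear on it.

Working notes on the chlorinated series. In a functional assay on P388 cells (Mus musculus) for cytotoxicity, read by MTT assay, with a stated time of 72 h (on this read-out higher numbers stand for weaker inhibition and lower numbers for stronger inhibition), compound 1, `C/C=C(\Cl)C(=O)[C@@](C)(O)[C@H]1CC(=O)C(C)=C2C=C(/C=C/[C@@H](C)[C@@H](C)O)OC=C21`, gives 0.0007 nM. Compound 2, `C[C@H](O)[C@@H](C)/C=C/C1=CC2=C(Cl)C(=O)[C@](C)(O)[C@@H](O)[C@@H]2CO1`, gives 0.032 nM in this assay. Compound 3, `C/C=C(\C)C(=O)C[C@H]1C2=COC(/C=C/[C@H](C)[C@@H](C)O)=CC2=C(Cl)C(=O)[C@@]1(C)O`, gives 0.0007 nM in this assay, which leaves it level with compound 1 at the digits shown, the pair together at the low end of the three numbers, while compound 2 sits much higher, a gap beyond the scatter. Compound 4, `C/C=C(\C)C(=O)C[C@H]1C2=COC(/C=C/[C@@H](C)[C@@H](C)O)=CC2=C(Cl)C(=O)[C@@]1(C)O`, has not yet been run in this assay. Its relation to compound 3 is the two compounds have the same atoms and bonds and differ only in configuration as drawn: 1 of 6 stereo elements differ; a stereocentre at a saturated chain carbon is drawn S in compound 3 and R in compound 4. Within the data shown here, with no measured pair differing only in this configuration, the size of such a change cannot be read from the data. The expectation is that the step from compound 3 to compound 4 in this assay will stay near the scatter, with no settled direction, so a 1.4-fold higher number from compound 3 to compound 4 (0.15 log units; within the scatter) is estimated. Compound 4 is accordingly expected to give about 0.001 nM in this assay, with a range from 0.0003 nM to 0.004 nM.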

Compound 4, half-maximal inhibitory concentration: 0.0011 nM
Beside the measured number, compound 4's estimate is 1.1-fold (0.04 log units) below it; measured number inside the range.
By their numbers in this assay, from the lowest: compounds 1, 3 and 4 (each within the scatter of the next); then compound 2.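

In this assay the series now has its first measured step at a single place, a 1.6-fold higher number from compound 3 to compound 4 (0.20 log units; within the scatter), a change in configuration alone at a saturated chain carbon. For this pair, inverting that one stereocentre keeps the numbers within the scatter of each other, so this assay does not separate the two drawn configurations at that carbon. The step can be assigned to that centre and to nothing else in the structures: the fact that compounds 3 and 4 differ only in the configuration as drawn

From the compounds shown here alone, the other stereo elements remain untested on their own, so this result cannot be carried over to them. The compounds shown also leave open whether the same chain would keep the number in this range if it carried an amine or a carboxylic acid, or if a longer chain stood in its place.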